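A few compounds are considered here, and "the series" means these few. Any claim that something is new, unique, unknown or untested is made for them only; others in the source may bear on it.

Compound 2 `Clc1ccc(/C=N/N(Cc2ccccc2)Cc2ccccc2)cc1` gives 240 nM in an assay on liver (Sus scrofa) for inhibition of glucose-6-phosphatase catalytic subunit 1 (Homo sapiens), using microsomes (a higher number here means a weaker inhibitor, a lower number a stronger inhibitor), and stands lowest of the three numbers measured. Compound 1 `c1ccc(CN(Cc2ccccc2)/N=C2\CCCc3ccccc32)cc1` gives 25000 nM in this assay, and compound 3 `CN(C)c1ccc(/C=N/N(Cc2ccccc2)Cc2ccccc2)cc1` gives 100000 nM; both lie far above compound 2, beyond the scatter. Within the data shown here, only one single-place step has been measured: dimethylamino in place of chloro on an aromatic carbon produced a 420-fold higher number from compound 2 to compound 3 (2.62 log units; beyond the scatter), a large change for a single swap on that ring. Among the measured compounds shown here, compound 1 differs from compound 2 in more than one place, so its value shows only that compound 2 is the stronger of the two.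

Compound 4 `C(=N/N(Cc1ccccc1)Cc1ccccc1)\c1ccco1` is compound 2 with furan-2-yl in place of 4-chlorophenyl on a carbon with a double bond to nitrogen. For the measured compounds named here, the one step that bears on this position, the change from compound 2 to compound 3, shows the assay reacts strongly to what sits on the carbon double-bonded to nitrogen, so replacing the whole ring is expected to move the number well beyond the scatter, most plausibly upward because the only measured change at this ring gave a 420-fold higher number from compound 2 to compound 3 (2.62 log units; beyond the scatter). The step from compound 2 to compound 4 is therefore estimated at a 6.3-fold higher number from compound 2 to compound 4 (0.80 log units; beyond the scatter). Compound 4 is expected to give about 1500 nM in this assay, between 250 nM and 15000 nM.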

Compound 4, half-maximal inhibitory concentration: 1100 nM
For compound 4 the middle estimate is 1.4-fold (0.13 log units) above the measured one, and the stated range covers the measured number.
By their numbers in this assay, from the lowest: compound 2; then compound 4; then compound 1; then compound 3.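

Replacing the entire 4-chlorophenyl with furan-2-yl on a carbon with a double bond to nitrogen changes the number less than the earlier swap on that ring did: in this assay the change is a 4.6-fold higher number from compound 2 to compound 4 (0.66 log units; beyond the scatter) and counts as modest, against a 420-fold higher number from compound 2 to compound 3 (2.62 log units; beyond the scatter) for dimethylamino in place of chloro, which counts as large. Among these compounds, the earlier step left the ring itself in place, so this is the first reading of what happens when the ring is exchanged. This position accepts a five-membered aromatic ring with one hetero atom and no chlorine at a modest change, although the step still lies beyond the scatter and compound 2 keeps the lowest of the four numbers.

The swap removes the chlorine, shrinks the ring and brings in the ring oxygen all at once, and the compounds shown do not separate these changes, as an unsubstituted phenyl or a thiophen-2-yl might. Nor do they tell whether bromine in place of the chlorine, or a carboxylic acid on the furan, would move the number up or down. No measurement offered here accounts for the size of either step.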